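Removing a Cyclohexyl Group: Effect on Cell Tolerance

The source may hold more compounds than are shown below. What is called first, only, known or untested is meant among the compounds shown, and "the series" means these compounds.

Measured compounds, each in an ADME assay on MT4 cells (Homo sapiens) for cytotoxicity, read by MTT assay, with a stated time of 96 h; a higher number here means that more compound is tolerated, a lower number that less compound is tolerated:
Compound 1 `CCC(=O)Nc1ccc(-c2nc3cc(C(F)(F)F)ccc3n2C2CCCCC2)cc1` gives 17000 nM.
Compound 2 `CCC(=O)Nc1ccc(-c2nc3cc(C(F)(F)F)ccc3[nH]2)cc1` gives >= 100000 nM, which is a limit of the assay rather than a number.
Compound 3 `CC(=O)Nc1ccc(-c2nc3cc(C(F)(F)F)ccc3n2C2CCCCC2)cc1` gives 24000 nM.

Two changes link these compounds. Going from compound 1 to compound 2 the change is hydrogen in place of cyclohexyl on an aromatic nitrogen, and it produced an at least 5.8-fold higher number from compound 1 to compound 2 (0.76 log units; beyond the scatter); the value of compound 2 sits at the limit of >= 100000 nM in this assay, at which 1 of the 3 values shown sits, so the true step may be larger than shown. Going from compound 1 to compound 3 the change is hydrogen in place of methyl on a saturated chain carbon bound to a carbonyl carbon, and it gave a 1.4-fold higher number from compound 1 to compound 3 (0.15 log units; within the scatter), so these two compounds cannot be told apart in this assay.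

Compound 4 `CC(=O)Nc1ccc(-c2nc3cc(C(F)(F)F)ccc3[nH]2)cc1` has not yet been measured. For the measured compounds named here, it differs from compound 3 by hydrogen in place of cyclohexyl on an aromatic nitrogen, the same change at the same place as the one from compound 1 to compound 2. Since compound 3 and compound 1 lie within the scatter of each other, compound 4 is expected to behave like compound 2: the expected step is a 5.8-fold higher number from compound 3 to compound 4 (0.77 log units; beyond the scatter), beside the measured at least 5.8-fold higher number from compound 1 to compound 2 (0.76 log units; beyond the scatter). The estimate for compound 4 is 140000 nM, between 60000 nM and 400000 nM, and most likely the assay will again report only a limit.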

Compound 4, half-maximal cytotoxic concentration: 19000 nM
Beside the measured number, compound 4's estimate is 7.4-fold (0.87 log units) above it; measured number below the stated range.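

On the core of compound 3, the swap of cyclohexyl for hydrogen in this assay gave a 1.3-fold lower number from compound 3 to compound 4 (0.10 log units; within the scatter), so this change does not carry over from one core to the other: the same change on two cores in this assay, an at least 5.8-fold higher number (0.76 log units; beyond the scatter) from compound 1 to compound 2 and a 1.3-fold lower number (0.10 log units; within the scatter) from compound 3 to compound 4, at least 7.4-fold (0.87 log units) apart, beyond the scatter of two such steps

The other change, hydrogen in place of methyl, gave an at least 5.2-fold lower number from compound 2 to compound 4 (0.72 log units; beyond the scatter) on the core without cyclohexyl, so it does not carry over either: the same change on two cores in this assay, a 1.4-fold higher number (0.15 log units; within the scatter) from compound 1 to compound 3 and an at least 5.2-fold lower number (0.72 log units; beyond the scatter) from compound 2 to compound 4, at least 7.4-fold (0.87 log units) apart, beyond the scatter of two such steps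

Compound 2 gives >= 100000 nM, which is a limit of the assay and not a number, and these few pairs show that the effect of each change depends on the other group present, but they do not show why, or whether this holds for other groups in the series.

The compounds shown leave open how a small group such as methyl, or a longer carbon chain, would behave on the aromatic nitrogen in place of cyclohexyl. They also leave open whether an amine on the chain bound to the carbonyl would follow compound 2 or compound 4.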